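Extending the methylamino group of compound 3 by one carbon

The compounds below may be only part of what the source reports. "The series", "measured", "known", "first", "only" and "open" are said of these compounds alone.

Compound 3 `CNc1nccnc1-c1cc(Cl)ccc1NS(=O)(=O)c1ccc(C(C)(C)C)cc1` shows the lowest number of the three compounds measured in a functional assay on isolated protein for antagonist activity at C-C chemokine receptor type 9 (Homo sapiens), read by calcium flux, with a stated time of 10 min (on this read-out higher numbers stand for weaker inhibition and lower numbers for stronger inhibition), where compound 3 gives 25 nM. Compound 2 `CNc1ncc(O)c(-c2cc(Cl)ccc2NS(=O)(=O)c2ccc(C(C)(C)C)cc2)n1` gives 27 nM, a difference from compound 3 within the scatter, while compound 1 `CC(C)(C)c1ccc(S(=O)(=O)Nc2ccc(Cl)cc2-c2nccc(C(N)=O)c2O)cc1` gives 52 nM; the step of a 2.1-fold lower number from compound 1 to compound 3 (0.32 log units; beyond the scatter) is modest. Compound 4 `CCNc1nccnc1-c1cc(Cl)ccc1NS(=O)(=O)c1ccc(C(C)(C)C)cc1` differs from compound 3 by methyl in place of hydrogen on a saturated chain carbon bound to a nitrogen on an aromatic ring, that is, methylamino becomes ethylamino. Going by the values given here, none of the measured steps touches this chain: all of them swap one aromatic ring for another, as in a 1.9-fold lower number from compound 1 to compound 2 (0.28 log units; within the scatter) and a 1.1-fold lower number from compound 2 to compound 3 (0.03 log units; within the scatter). Among the compounds with values here, with no step of this kind measured, the expectation for compound 4 in this assay is a step of no change at the digits printed from compound 3 to compound 4 (within the scatter), nothing beyond the scatter. The estimate for compound 4 is therefore 25 nM, with a range from 10 nM to 60 nM.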

Compound 4, half-maximal inhibitory concentration: 421 nM
The estimate for compound 4 lay 17-fold (1.23 log units) below the measured number, outside the stated range (above it).
By their numbers in this assay, from the lowest: compounds 3, 2 and 1 (each within the scatter of the next, the first and the last beyond it); then compound 4.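

In this assay the methyl that turns methylamino into ethylamino gives a 17-fold higher number from compound 3 to compound 4 (1.23 log units; beyond the scatter) and so shows that this short chain tolerates far less change than the earlier ring swaps suggested. Compound 4 also sits apart from the compounds with other rings, with a 16-fold higher number from compound 2 to compound 4 (1.19 log units; beyond the scatter) and an 8.1-fold higher number from compound 1 to compound 4 (0.91 log units; beyond the scatter) as well, so one added carbon here outweighs every ring difference seen so far. Nothing on hand explains this loss. As far as these compounds go, whether a plain amine would match methylamino remains open, as does whether a longer chain such as propylamino would fall further still.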